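The source may report more compounds than this note shows. Statements on the series, on what has been measured and on what is new or still open speak of the compounds shown alone.

Measured so far in a functional assay on PC-3 cells (Homo sapiens) for inhibition, read by MTT assay, with a stated time of 72 h; on this read-out higher numbers stand for weaker inhibition and lower numbers for stronger inhibition:

Compound 1 `O=C(CSc1nc(Nc2ccccc2)c2ccccc2n1)Nc1cccc(F)c1` gives 15600 nM.
Compound 2 `CCc1cccc(NC(=O)CSc2nc(Nc3ccccc3)c3ccccc3n2)c1` gives 11000 nM.
Compound 3 `COc1cccc(NC(=O)CSc2nc(Nc3ccccc3)c3ccccc3n2)c1` gives 11600 nM.

All three share the same core and differ only in the group on the aromatic ring attached to the amide-type nitrogen. Compound 3 sits second highest of the three numbers in this assay, but its neighbours are close: the step of a 1.1-fold higher number from compound 2 to compound 3 (0.02 log units; within the scatter) and the step of a 1.3-fold lower number from compound 1 to compound 3 (0.13 log units; within the scatter) are both within the scatter, so the three compounds cannot be ordered on these data.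

Compound 4 `O=C(CSc1nc(Nc2ccccc2)c2ccccc2n1)Nc1ccc(Cl)cc1` is not yet measured. The change from compound 3 is 4-chlorophenyl in place of 3-methoxyphenyl on an amide-type nitrogen. Among the measured compounds shown here, none of the measured steps covers this exact exchange: a 1.4-fold lower number from compound 1 to compound 2 (0.15 log units; within the scatter) and a 1.3-fold lower number from compound 1 to compound 3 (0.13 log units; within the scatter) show that swapping one small group for another at the aromatic carbon in question left the number within the scatter, while the pair compound 3 to compound 4 alters both the group and its place on the ring, which no measured pair probes. With nothing in the series pointing to a shift, the step of a 1.0-fold higher number from compound 3 to compound 4 (0.01 log units; within the scatter) is expected to stay within the scatter. Compound 4 is therefore estimated at 12000 nM in this assay, with a range from 5000 nM to 30000 nM.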

Compound 4, half-maximal inhibitory concentration: 12900 nM
Compound 4: middle estimate off by 1.1-fold (0.03 log units), on the low side; measured number inside the range.
By their numbers in this assay, from the lowest: compounds 2, 3, 4 and 1 (each within the scatter of the next).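

In this assay, among the compounds shown here, the earlier compounds carry only 3-fluorophenyl, 3-ethylphenyl or 3-methoxyphenyl on the amide-type nitrogen, and 4-chlorophenyl adds both a chlorine and a different ring numbering, yet the exchange for 3-methoxyphenyl gives a 1.1-fold higher number from compound 3 to compound 4 (0.05 log units; within the scatter). The comparisons with the other two groups read the same way, with a 1.2-fold higher number from compound 2 to compound 4 (0.07 log units; within the scatter) and a 1.2-fold lower number from compound 1 to compound 4 (0.08 log units; within the scatter), so all four aryl groups at this place remain indistinguishable in this assay and the change of both substituent and numbering opens no measurable gap. Nothing further is at hand to explain why the numbers stay together.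

Going by these compounds, whether chlorine or the numbering alone matters stays open, as a pair such as 3-chlorophenyl and 4-chlorophenyl would be needed to separate them, and the shared core offers no comparison here. Also open, on these data alone, is whether a group of another kind on this nitrogen, such as a phenyl ring bearing an amine or a carboxylic acid, or a longer chain in place of the ring, would move the number beyond the scatter.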